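From 3-fluorophenyl to 3-methylphenyl: no large step expected

The compounds below may be only part of what the source reports. "The series", "measured", "known", "first", "only" and "open" are said of these compounds alone.

In a functional assay on HepG2 cells (Homo sapiens) for antiproliferative activity, read by MTT assay, with a stated time of 48 h (a higher number here means a weaker inhibitor, a lower number a stronger inhibitor), compound 1 (`COc1ccc(N(Cc2noc(-c3ccccc3)n2)C(=O)CCCCCC(=O)NO)cc1`) gives 1070 nM and compound 2 (`COc1ccc(N(Cc2noc(-c3cccc(F)c3)n2)C(=O)CCCCCC(=O)NO)cc1`) gives 1030 nM on the same read-out. Among the compounds with values here, the single measured step reads a 1.0-fold lower number from compound 1 to compound 2 (0.02 log units; within the scatter) for fluoro in place of hydrogen on an aromatic carbon, so compound 2 stands level with compound 1 and their two numbers cannot be told apart.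

Compound 3 (`COc1ccc(N(Cc2noc(-c3cccc(C)c3)n2)C(=O)CCCCCC(=O)NO)cc1`) differs from compound 2 by methyl in place of fluoro on an aromatic carbon, the change from 3-fluorophenyl to 3-methylphenyl. Within the data shown here, only that one measured step bears on this change, and only in part, as no methyl compound has yet been measured in this set. The expectation rests on compound 2, whose step of a 1.0-fold lower number from compound 1 to compound 2 (0.02 log units; within the scatter) shows no shift beyond the scatter when that aromatic carbon takes a new group. No step beyond the scatter, in either direction, is therefore expected in this assay for this change. The expected step is a 1.0-fold higher number from compound 2 to compound 3 (0.01 log units; within the scatter) and no more. Compound 3 is estimated at 1050 nM with an expected range of 550 nM to 2000 nM in this measurement.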

Compound 3, half-maximal inhibitory concentration: 1680 nM
For compound 3 the middle estimate is 1.6-fold (0.20 log units) below the measured one, within the range that was stated.
By their numbers in this assay, from the lowest: compounds 2, 1 and 3 (each within the scatter of the next).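

In this assay, putting methyl in place of fluoro on this aromatic carbon gives a 1.6-fold higher number from compound 2 to compound 3 (0.21 log units; within the scatter), and putting methyl in place of hydrogen at the same carbon gives a 1.6-fold higher number from compound 1 to compound 3 (0.20 log units; within the scatter). Where the earlier compounds showed only that fluoro could stand here, compound 3 shows that a methyl group, also of one heavy atom but carbon rather than fluorine, stays within the scatter of both hydrogen and fluoro, so the three compounds cannot be told apart on this read-out and this place on the ring has so far shown no sensitivity to these small groups. Nothing available here speaks to why the numbers fall as they do.

As far as these compounds go, what remains open is whether a group of more heavy atoms at this carbon, such as a trifluoromethyl, a methoxy, an amine or a carboxylic acid, would also stay within the scatter or would produce a real step. The compounds shown also leave open whether methyl or fluoro would behave the same way elsewhere on this six-membered ring, or with a shorter or longer chain in the rest of the core.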